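Ester series: 2-methyloxiran-2-yl in place of 1-methylethenyl

The source may hold more compounds than are shown below. What is called first, only, known or untested is meant among the compounds shown, and "the series" means these compounds.

Measured so far:
compound 1 `C=C(C)[C@@H](OC(=O)c1ccc(OC)c2ccc(OC)cc12)C(N)=O` gives > 100000 nM
compound 2 `C=C(C)[C@@H](OC(=O)c1ccc(C)c2ccccc12)C(N)=O` gives > 100000 nM

Both values come from a functional assay on CHO cells (Cricetulus griseus) for inhibition, read by MTT assay, with a stated time of 96 h (a lower number here means a stronger inhibitor, a higher number a weaker inhibitor), and both are limits of that assay rather than numbers. For compound 1 the reported value is a limit, > 100000 nM. For compound 2 the reported value is likewise a limit, > 100000 nM. Among the compounds with values here, compound 1 therefore stands at the limit of > 100000 nM in this assay, at which 2 of the 2 values shown sit; no ranking between the two measured compounds is possible on these data, and no step between measured compounds can be read.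

Not yet measured is compound 3 `COc1ccc2c(OC)ccc(C(=O)O[C@@H](C(N)=O)C3(C)CO3)c2c1`. It differs from compound 1 in one place: 2-methyloxiran-2-yl in place of 1-methylethenyl on a saturated chain carbon bound to a carbonyl carbon and an oxygen next to a carbonyl group.

With nothing but limits to go on, and both measured values sitting at the same limit, no basis exists for expecting a step beyond the scatter in either direction in this assay. Compound 3 is accordingly expected to stay at the limit, with an estimated value of 100000 nM (range 20000 nM to 500000 nM), which means an expected step of a number no higher from compound 1 to compound 3 (the limit leaves the size open).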

Compound 3, half-maximal inhibitory concentration: 3000 nM
Compound 3: middle estimate off by 33-fold (1.52 log units), on the high side; the measured number lies below the stated range.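

Position note: this is the first change in the series to move the read-out off the limit. In this assay, 2-methyloxiran-2-yl in place of 1-methylethenyl on a saturated chain carbon bound to a carbonyl carbon and an oxygen next to a carbonyl group gives an at least 33-fold lower number from compound 1 to compound 3 (1.52 log units; beyond the scatter). From the compounds shown here alone, compound 1 gives > 100000 nM, which is a limit of the assay and not a number, so the true size of the step stays open. The earlier compounds could show no response to any change at this position, and no step between them can be read: the limit of > 100000 nM in this assay, at which 2 of the 3 values shown sit.

The compounds shown do not separate the contribution of the three-membered ring from that of its oxygen, a question that a 1-methylcyclopropyl group, which has the ring but no oxygen, or an open-chain 1,2-dihydroxy-2-methylethyl group, which has oxygen but no ring, would address. Going by these compounds, it also remains open whether the same replacement lowers the number on the core of compound 2, or whether a longer chain on the oxirane carbon in place of its methyl is tolerated.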